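The compounds below may be only part of what the source reports. "The series", "measured", "known", "first", "only" and "open" are said of these compounds alone.

Among the compounds with values here, compound 1 `COc1cc(-c2ccnc3cc(-c4ccc(C)cc4)nn23)cc(OC)c1OC` gives 21 nM in a functional assay on HeLa cells (Homo sapiens) for inhibition, read by CCK-8 assay, with a stated time of 48 h (a higher number here means a weaker inhibitor, a lower number a stronger inhibitor), the lowest of the three numbers measured so far. Compound 2 `COc1ccc(-c2cc3nccc(-c4cc(OC)c(OC)c(OC)c4)n3n2)cc1F` gives 236 nM and compound 3 `COc1cc(-c2ccnc3cc(-c4ccc5ccn(C)c5c4)nn23)cc(OC)c1OC` gives 187 nM in this assay; the steps of an 11-fold higher number from compound 1 to compound 2 (1.05 log units; beyond the scatter) and an 8.9-fold higher number from compound 1 to compound 3 (0.95 log units; beyond the scatter) both run upward from compound 1 and both lie beyond the scatter. Compound 4 `COc1cc(-c2ccnc3cc(-c4ccc(F)cc4)nn23)cc(OC)c1OC` differs from compound 1 by fluoro in place of methyl on an aromatic carbon. Within the data shown here, no measured step exchanges one small group for another at this place; the two measured steps from compound 1 instead replaced 4-methylphenyl with a larger group and raised the number each time. A smaller rise, or none beyond the scatter, is therefore expected for compound 4, estimated at 40 nM within 15 nM to 120 nM, a step of a 1.9-fold higher number from compound 1 to compound 4 (0.28 log units; within the scatter).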

Compound 4, half-maximal inhibitory concentration: 5840 nM
Estimate against measurement, compound 4: 150-fold (2.16 log units) below; measured number outside the range, above it.
By their numbers in this assay, from the lowest: compound 1; then compounds 3 and 2 (each within the scatter of the next); then compound 4.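

In this assay, the exchange of methyl for fluoro on the aromatic carbon para to a large group gives a 280-fold higher number from compound 1 to compound 4 (2.44 log units; beyond the scatter), a larger step than any earlier one, so this position responds strongly even to a small exchange, and not only to larger groups. The 4-fluorophenyl compound also lies well above both larger replacements, with a 31-fold higher number from compound 3 to compound 4 (1.49 log units; beyond the scatter) and a 25-fold higher number from compound 2 to compound 4 (1.39 log units; beyond the scatter). No measurement shown here accounts for this result.

From the compounds shown here alone, whether methyl itself is special stays open, since chloro, ethyl or an amine at this place would test that reading.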